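Bromo for Chloro on the Aryl Ring of Compound 1

A few compounds are considered here, and "the series" means these few. Any claim that something is new, unique, unknown or untested is made for them only; others in the source may bear on it.

Compound 1, `CCCCCOC1(c2ccc(Cl)cc2)SC=C(C)n2c1noc2=O`: a limit only in a functional assay on A2780/DX3 cells (Homo sapiens) for antiproliferative activity, read by MTT assay, with a stated time of 3 days (on this read-out higher numbers stand for weaker inhibition and lower numbers for stronger inhibition), > 100000 nM
Compound 2, `CC/C=C/COC1(c2ccc(Cl)cc2)SC=C(C)n2c1noc2=O`: 88000 nM in this assay

Compound 1 sits at the assay limit, (the limit of > 100000 nM in this assay, at which 1 of the 2 values shown sits), so no number is known for it. Among the measured compounds shown here, the only measured step, an at least 1.1-fold lower number from compound 1 to compound 2 (0.05 log units; that floor lies within the scatter), concerns the chain on the oxygen, not the aryl ring. Compound 3, `CCCCCOC1(c2ccc(Br)cc2)SC=C(C)n2c1noc2=O`, differs from compound 1 by bromo in place of chloro on an aromatic carbon. For the measured compounds named here, no measured step bears on this halogen change, so no shift beyond the scatter is expected, a number no higher from compound 1 to compound 3 (the limit leaves the size open). Compound 3 is therefore estimated at 100000 nM, between 40000 nM and 300000 nM, most likely again reported as a limit.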

Compound 3, half-maximal inhibitory concentration: > 100000 nM
Compound 3: a limit, no number (the forecaster's own chance of this, stated with the estimate: 65%); the middle value sits exactly at the limit.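

Compound 1 and compound 3 both give only a limit, so no step can be read between them: the limit of > 100000 nM in this assay, at which 2 of the 3 values shown sit.

The compounds shown leave open whether bromo in place of chloro on the aryl ring changes the result in this assay at all.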